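Removing an isopropoxy group from a cytotoxic dienone

A few compounds are considered here, and "the series" means these few. Any claim that something is new, unique, unknown or untested is made for them only; others in the source may bear on it.

Compound 1 `COc1ccc(C2=C(c3cc(OC)c(OC)c(OC)c3)C(=O)C(O[SiH2]C(C)(C)C)C2)cc1OC(C)C`: 9 ug/mL
Compound 2 `COc1ccc(C2=C(c3cc(OC)c(OC)c(OC)c3)CC(O)C2=O)cc1[N+](=O)[O-]`: > 100 ug/mL

Of the compounds shown here, two have been tested in an ADME assay on HT-29 cells (Homo sapiens) for cytotoxicity, read by MTT assay, with a stated time of 72 h; on this read-out lower numbers stand for stronger inhibition and higher numbers for weaker inhibition. Compound 1 gives 9 ug/mL in this assay, and this is the only number shown. For compound 2 the read-out is a limit rather than a number: the limit of > 100 ug/mL in this assay, at which 1 of the 2 values shown sits. Among the measured compounds shown here, compound 1 and compound 2 differ in more than one place, so no single structural step between measured compounds can be read from them.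

Compound 3 `COc1ccc(C2=C(c3cc(OC)c(OC)c(OC)c3)C(=O)C(O[SiH2]C(C)(C)C)C2)cc1` has not yet been measured. It differs from compound 1 in one place: hydrogen in place of isopropoxy on an aromatic carbon. For the measured compounds named here, with no measured step to lean on, the expectation rests on the isopropoxy group being a sizeable piece of compound 1. For compound 3 the expected step is a 2.2-fold higher number from compound 1 to compound 3 (0.35 log units; beyond the scatter), a loss that may not reach beyond the usual scatter. Compound 3 is therefore estimated at 20 ug/mL, with a likely range from 6 ug/mL to 60 ug/mL.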

Compound 3, half-maximal inhibitory concentration: 5 ug/mL
Beside the measured number, compound 3's estimate is 4.0-fold (0.60 log units) above it; measured number outside the range, below it.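

Replacing isopropoxy with hydrogen on this aromatic carbon gives a 1.8-fold lower number from compound 1 to compound 3 (0.26 log units; within the scatter) in this assay. Among the compounds shown here, this is the first comparison here that changes only one place, and it shows that the whole isopropoxy group can go without a difference that stands clear of the scatter. At this position of the core, then, the read-out does not depend on having that group in place, at least for this pair. Nothing measured here offers a reason for this result.

From the compounds shown here alone, only isopropoxy and hydrogen are seen at this carbon, so it remains open how a smaller or more charged group, such as a hydroxyl, an amine or a carboxylic acid, would read there. Going by these compounds, it is also open whether the same change would read alike on a different core.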